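This account rests on a few compounds, and the source may have more. Where it says the series, first, only, none or still open, it means among the compounds named here.

Compound 1 `CCCCCOc1c(-c2cc(OC)c(OC)c(OC)c2)oc2ccccc2c1=O`: 15400 nM
Compound 2 `COc1cc(-c2oc3ccccc3c(=O)c2OC(C)C)cc(OC)c1OC`: 8800 nM
Compound 3 `CCCCN(CCCC)CCCOc1c(-c2cc(OC)c(OC)c(OC)c2)oc2ccccc2c1=O`: 9000 nM

These three compounds were tested in a functional assay on LNCaP cells (Homo sapiens) for antiproliferative activity, read by WST assay, with a stated time of 3 days; on this read-out higher numbers stand for weaker inhibition and lower numbers for stronger inhibition. Compound 1 gives the highest number of the three, but its neighbours lie close: the step of a 1.8-fold lower number from compound 1 to compound 2 (0.24 log units; within the scatter) and the step of a 1.7-fold lower number from compound 1 to compound 3 (0.23 log units; within the scatter) are both within the scatter, so none of the three can be separated from the others on these numbers alone. The step of a 1.0-fold higher number from compound 2 to compound 3 (0.01 log units; within the scatter) is likewise within the scatter.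

Compound 4 `CCCCCN(CCCCC)CCCCCOc1c(-c2cc(OC)c(OC)c(OC)c2)oc2ccccc2c1=O` has not yet been measured. It differs from compound 1 by dipentylamino in place of hydrogen on a saturated chain carbon, five bonds along the chain from an oxygen on an aromatic ring. Within the data shown here, the measured step that bears most on this change is the one from compound 1 to compound 3, where a dibutylamino group enters three bonds along the chain from the aromatic oxygen, and that step stayed within the scatter. Among the measured compounds shown here, the change to compound 4 is a larger dialkylamino group placed further out on a longer chain, for which no measured step exists, so any expectation rests on the single comparable step alone.

Given that, compound 4 is expected to show a step of about a 1.5-fold lower number from compound 1 to compound 4 (0.19 log units; within the scatter), that is, no change beyond the scatter. The estimate for compound 4 is 10000 nM, within a range from 4000 nM to 25000 nM.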

Compound 4, half-maximal inhibitory concentration: 7900 nM
The estimate for compound 4 lay 1.3-fold (0.10 log units) above the measured number; measured number inside the range.
By their numbers in this assay, from the lowest: compounds 4, 2, 3 and 1 (each within the scatter of the next).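

In this assay, the step of a 1.9-fold lower number from compound 1 to compound 4 (0.29 log units; within the scatter) shows that placing dipentylamino, a group of 11 heavy atoms, on a saturated chain carbon five bonds along the chain from an oxygen on an aromatic ring does not move the number beyond the scatter. Among these compounds, until now, the only comparable evidence was the step of a 1.7-fold lower number from compound 1 to compound 3 (0.23 log units; within the scatter), with dibutylamino three bonds along the chain, so the same outcome now holds for a second amine, at a second place on the chain, in this pair of comparisons. Nothing available here explains this outcome.

The compounds shown leave open whether any group at that place can separate itself from compound 1 in this assay, for instance a carboxylic acid, a morpholine or a primary amine on the same five-bond chain. They also leave open how dipentylamino reads on a shorter chain, or dibutylamino on the longer one, since those pairings would separate the effect of the amine from that of the chain.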